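Methyl for Methoxy: an Expected Half-life for Compound 4

The compounds below may be only part of what the source reports. "The series", "measured", "known", "first", "only" and "open" are said of these compounds alone.

Compound 1 `COc1cnc(C[S+]([O-])c2nc3cc(OC(F)F)ccc3[nH]2)c(C)c1OC`: 3.7 h
Compound 2 `COc1c(C)cnc(C[S+]([O-])c2nc3cc(OC(F)F)ccc3[nH]2)c1C`: 1.9 h
Compound 3 `COc1ccnc(C[S+]([O-])c2nc3cc(F)c(OC(F)F)cc3[nH]2)c1OC`: 8.3 h

These three were measured in an ADME assay, at pH 5; a higher number here means that the compound lasts longer, a lower number that the compound disappears faster. From compound 1 to compound 2 the change is methyl in place of methoxy on an aromatic carbon, and it gave a 1.9-fold lower number from compound 1 to compound 2 (0.29 log units; within the scatter). Compound 4 `COc1ccnc(C[S+]([O-])c2nc3cc(F)c(OC(F)F)cc3[nH]2)c1C` is not yet measured; it arises from compound 3 by methyl in place of methoxy on an aromatic carbon. This is the same kind of change, though not the same: in compound 4 the site is ortho to a large group, whereas in compound 2 it is meta to a methyl group and para to a large group. The difference between the core of compound 1 and the core of compound 3 is not broken down here. Compound 3 holds the highest number of the three. Among the compounds with values here, for compound 4 a step of a 1.8-fold lower number from compound 3 to compound 4 (0.27 log units; within the scatter) is expected, because a 1.9-fold lower number from compound 1 to compound 2 (0.29 log units; within the scatter) is the only guide available, and it lies within the scatter, so the direction is uncertain. The estimate for compound 4 in this assay is therefore 4.5 h, with a range from 2.5 h to 8.5 h.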

Compound 4, half-life: 0.5 h
Compound 4: middle estimate off by 9.0-fold (0.95 log units), on the high side; the whole stated range lies above it.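

In this assay, methyl in place of methoxy gives a 17-fold lower number from compound 3 to compound 4 (1.22 log units; beyond the scatter), a large step. This change therefore cannot be carried from one core to another in this series with a fixed size, as the two steps set side by side show: the same change on two cores in this assay, a 1.9-fold lower number (0.29 log units; within the scatter) from compound 1 to compound 2 and a 17-fold lower number (1.22 log units; beyond the scatter) from compound 3 to compound 4, 8.5-fold (0.93 log units) apart, beyond the scatter of two such steps

What this does not show is the reason for the gap: the two pairs differ both in the rest of the core and in where the change sits on the ring, and these two differences cannot be separated here. The compounds shown leave open how each of these differences contributes on its own. They also leave open how this assay would respond to a different group at the same place, such as ethoxy, chlorine or an amine.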